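The compounds below may be only part of what the source reports. "The series", "measured", "known", "first", "only" and "open" are said of these compounds alone.

Compound 1, `CCCc1ccc(NC2=CC(=O)c3nc4n(c3C2=O)[C@H]2OC[C@@H](O)[C@H]2OC4)cc1`, gives 4990 nM in a functional assay on HeLa cells (Homo sapiens) for inhibition, read by sulforhodamine B assay; on this read-out higher numbers stand for weaker inhibition and lower numbers for stronger inhibition. Compound 2, `O=C1C(Nc2ccccc2F)=CC(=O)c2c1nc1n2[C@H]2OC[C@@H](O)[C@H]2OC1`, gives 9820 nM in this assay, a value within the usual scatter of compound 1, so the two cannot be told apart. Compound 3, `O=C1C(N2CCC2)=CC(=O)c2c1nc1n2[C@H]2OC[C@@H](O)[C@H]2OC1`, is reported in this assay only as a limit, > 16000 nM, which is the limit of > 16000 nM in this assay, at which 1 of the 3 values shown sits. Going by the values given here, the single measured step, an at least 1.6-fold higher number from compound 2 to compound 3 (0.21 log units; that floor lies within the scatter), concerns a quite different kind of change and does not resemble the one studied here. Compound 4, `COc1ccc(NC2=CC(=O)c3nc4n(c3C2=O)[C@H]2OC[C@@H](O)[C@H]2OC4)cc1`, differs from compound 1 by methoxy in place of propyl on an aromatic carbon. Among the compounds with values here, with no measured step of this sort to lean on, no movement beyond the scatter is expected. Compound 4 is therefore estimated to give 6000 nM, between 2500 nM and 16000 nM. The estimated step is a 1.2-fold higher number from compound 1 to compound 4 (0.08 log units; within the scatter).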

Compound 4, half-maximal inhibitory concentration: 4780 nM
Beside the measured number, compound 4's estimate is 1.3-fold (0.10 log units) above it, within the range that was stated.
By their numbers in this assay, from the lowest: compounds 4, 1 and 2 (each within the scatter of the next, the first and the last beyond it). At a limit, above all of these: compound 3.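

In this assay, the change from 4-propylphenyl to 4-methoxyphenyl gives a 1.0-fold lower number from compound 1 to compound 4 (0.02 log units; within the scatter), the first step shown at this position, para to a large group. Propyl, with no hydrogen-bond acceptor, and methoxy, with one, thus give values that cannot be told apart. Nothing given here accounts for this result.

On these data alone, whether an amine, a carboxylic acid or a longer chain at this position would stay within the scatter remains open. So does whether a hydroxyl group or a chlorine atom there would do the same.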